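Replacing chloro by a methoxycarbonylmethyl chain on the shared core

A few compounds are considered here, and "the series" means these few. Any claim that something is new, unique, unknown or untested is made for them only; others in the source may bear on it.

Of the compounds shown here, two on the shared core have been measured in a functional assay on the whole organism (stomach) for inhibition, with Canis familiaris (Canis lupus familiaris) as the target, at a dose of 5 mg/kg by the intravenous route; on this read-out lower numbers stand for a weaker effect and higher numbers for a stronger effect at the one dose given. Compound 1 `Cc1nc2c(OCc3ccccc3)cccn2c1C(N)=O` gives 2%, and compound 2 `Cc1nc2c(OCc3ccccc3)cccn2c1Cl` gives 37%, the higher of the two numbers, with a number 35 percentage points higher from compound 1 to compound 2 (beyond the scatter) for the change of chloro in place of carbamoyl on an aromatic carbon. Compound 3 `COC(=O)Cc1c(C)nc2c(OCc3ccccc3)cccn12` differs from compound 2 by (methoxycarbonyl)methyl in place of chloro on an aromatic carbon. Within the data shown here, the one measured step bears only loosely on this change: going from carbamoyl to chloro raised the read-out by a large amount, and the present step again removes chloro in favour of a group that carries a carbonyl with two hydrogen-bond acceptors. By that comparison a fall beyond the scatter is expected, though not necessarily all the way back to the number of compound 1. Compound 3 is therefore estimated at 15%, within 0% to 40%, an expected step of a number 22 percentage points lower from compound 2 to compound 3 (beyond the scatter).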

Compound 3, a percentage reported as inhibition, in the whole organism at one dose (the size of the read-out at that dose, not a potency): 16%
For compound 3 the middle estimate is 1 percentage points below the measured one; low and high end bracket the measured number.
By their numbers in this assay, from the lowest: compound 1; then compound 3; then compound 2.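

In this assay, putting (methoxycarbonyl)methyl in place of chloro on this aromatic carbon gives a number 21 percentage points lower from compound 2 to compound 3 (beyond the scatter), so this chain does not match chloro at this position. The same chain set against carbamoyl gives a number 14 percentage points higher from compound 1 to compound 3 (beyond the scatter), which shows that the two carbonyl-bearing groups are not equivalent here and that the read-out at this position follows more than the presence of a carbonyl, with the ester chain lying between the other two groups. Nothing available explains either step.

On these data alone, it remains open whether the carboxylic acid of this chain, or a longer ester chain, would move the number toward that of compound 2 or toward that of compound 1. As far as these compounds go, it is equally open whether an amine on this carbon would match or surpass chloro.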